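A few compounds are considered here, and "the series" means these few. Any claim that something is new, unique, unknown or untested is made for them only; others in the source may bear on it.

Measured in a functional assay on MCF7 cells (Homo sapiens) for antiproliferative activity, read by MTT assay, with a stated time of 72 h; a higher number here means a weaker inhibitor, a lower number a stronger inhibitor:

- compound 1 `CC1=CCC2C(CC[C@@]2(C)O)C(C)(C)C1CC[C@@H]1[C@@]2(C)CC[C@@H](O)C(C)(C)O[C@@H]2CC[C@]1(C)O`: 44500 nM
- compound 2 `CC1=CC[C@H]2[C@@H]1CC=C(C)[C@@H](CC[C@H]1[C@]3(C)CC[C@H](O)C(C)(C)O[C@H]3CC[C@@]1(C)O)C2(C)C`: > 50000 nM
- compound 3 `CC1=CC[C@H]2[C@H](CC[C@]2(C)O)C(C)(C)[C@@H]1CC[C@H]1[C@]2(C)CC[C@H](OC(=O)CCC(=O)O)C(C)(C)O[C@H]2CC[C@@]1(C)O`: > 50000 nM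

Of the three, only compound 1 gives a number in this assay, 44500 nM, and that number already marks a weak inhibitor. Compound 2 reaches only the limit of the assay, > 50000 nM. Compound 3 likewise reaches only the limit, > 50000 nM. Compound 3 therefore stands at the limit of > 50000 nM in this assay, at which 2 of the 3 values shown sit, so its own potency cannot be placed more exactly than that it is no stronger than compound 1 appears to be. Among the measured compounds shown here, no pair of measured compounds differs in a single place, so no measured step is available to set a scale for the change considered here.

Compound 4 `CC1=CC[C@H]2[C@H](CC[C@]2(C)O)C(C)(C)[C@@H]1CC[C@H]1[C@]2(C)CC[C@H](OC(=O)c3cccc([N+](=O)[O-])c3)C(C)(C)O[C@H]2CC[C@@]1(C)O` differs from compound 3 in one place: 3-nitrophenyl in place of 2-carboxyethyl on a carbonyl carbon. With nothing measured to anchor this change, the expectation is weak activity again, with the number for compound 4 estimated at 35000 nM and its range at 12000 nM to 60000 nM. The expected step is an at least 1.4-fold lower number from compound 3 to compound 4 (0.15 log units; that floor lies within the scatter), that is, no change beyond the scatter, with the ester of compound 4 quite possibly reported only as a limit as well.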

Compound 4, half-maximal inhibitory concentration: 36000 nM
Compound 4: the middle estimate sits 1.0-fold (0.01 log units) below what was measured; the measured number falls inside the stated range.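

In this assay, the acyl position on the oxygen next to a carbonyl group now yields a measured number with (3-nitrophenyl)carbonyl, which compound 3, carrying (2-carboxyethyl)carbonyl, did not provide. The change reads as an at least 1.3-fold lower number from compound 3 to compound 4 (0.14 log units; that floor lies within the scatter), and since this is only a floor, the true size of the step may lie within the scatter or beyond it, so no gain in potency can be claimed from this pair. Compound 3 is held at a limit rather than a number, and that same limit recurs in the series: the limit of > 50000 nM in this assay, at which 2 of the 4 values shown sit.

Among the compounds shown here, the single pair does not separate the contribution of the aromatic ring from that of the nitro group, nor does it show whether the loss of the carboxylic acid of the 2-carboxyethyl group matters at all. From the compounds shown here alone, an unsubstituted benzoyl ester, an acyl group bearing an amine and a longer unbranched acyl chain would each test this position further, and whether any group here can move the core out of the weak range remains open.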